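This account rests on a few compounds, and the source may have more. Where it says the series, first, only, none or still open, it means among the compounds named here.

Compound 1, `Cc1nc2c3ccccc3ccc2c2nc3c(ccc4ccccc43)c(-c3ccccc3S)c12`, gives 89 ug/mL in a functional assay, read by spectrophotometry, with a stated time of 30 min; a lower number here means a stronger inhibitor, a higher number a weaker inhibitor.
Compound 2, `Cc1nc2c3ccccc3ccc2c2nc3c(ccc4ccccc43)c(C)c12`, gives 129 ug/mL.
Compound 3, `Cc1nc2c3ccccc3ccc2c2nc3c(ccc4ccccc43)c(-c3cccc4ccccc34)c12`, gives 111 ug/mL.

The three measured compounds share one core and differ only in the group carried on one aromatic carbon. Compound 1 stands at one end of a narrow spread: the step of a 1.2-fold higher number from compound 1 to compound 3 (0.10 log units; within the scatter) and the step of a 1.4-fold higher number from compound 1 to compound 2 (0.16 log units; within the scatter) both lie within the scatter, and so does a 1.2-fold lower number from compound 2 to compound 3 (0.07 log units; within the scatter). Taken together, replacing the whole 2-sulfanylphenyl group with methyl or with naphthalen-1-yl moves the number little.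

Compound 4, `Cc1nc2c3ccccc3ccc2c2nc3c(ccc4ccccc43)c(-c3ccccc3N)c12`, has not yet been measured. It differs from compound 1 by amino in place of sulfanyl on an aromatic carbon. Among the compounds with values here, no measured step exchanges sulfanyl for amino, so nothing speaks directly to this change. The steps that do bear on this position, a 1.4-fold higher number from compound 1 to compound 2 (0.16 log units; within the scatter) and a 1.2-fold higher number from compound 1 to compound 3 (0.10 log units; within the scatter), alter the group far more than the change to compound 4 does and still stay within the scatter. No step beyond the scatter is therefore expected in this assay. Compound 4 is expected to give about 100 ug/mL, between 50 ug/mL and 200 ug/mL. The expected step is a 1.1-fold higher number from compound 1 to compound 4 (0.05 log units; within the scatter).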

Compound 4, half-maximal inhibitory concentration: 95.4 ug/mL
Estimate against measurement, compound 4: 1.0-fold (0.02 log units) above; the range from low to high includes it.
By their numbers in this assay, from the lowest: compounds 1, 4, 3 and 2 (each within the scatter of the next).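

The direct exchange of sulfanyl for amino is a 1.1-fold higher number from compound 1 to compound 4 (0.03 log units; within the scatter) in this assay, so this swap of a single heavy atom, sulfur for nitrogen, does not separate the two compounds. The 2-aminophenyl group also stays within the scatter of both other groups at this position, with a 1.2-fold lower number from compound 3 to compound 4 (0.07 log units; within the scatter) and a 1.4-fold lower number from compound 2 to compound 4 (0.13 log units; within the scatter), so all four listed groups now give numbers that cannot be told apart. No evidence is available to explain why these numbers stay so close.

Going by these compounds, whether a carboxylic acid or a hydroxyl group in place of the amino group, or a longer chain such as aminomethyl, would produce a step beyond the scatter remains open. On these data alone, what a change elsewhere on the shared core would do also remains open.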